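Swapping the amide side group on compound 3

The source may report more compounds than this note shows. Statements on the series, on what has been measured and on what is new or still open speak of the compounds shown alone.

Compound 1 `Cc1c2c(n3c1CCN(C(=O)[C@H](C)N)CC[C@H](C)Nc1cc-3ccc1C(N)=O)CC(C)(C)CC2=O`: 0.433 h
Compound 2 `CC(=O)N1CCc2c(C)c3c(n2-c2ccc(C(N)=O)c(c2)N[C@@H](C)[C@H](C)C1)CC(C)(C)CC3=O`: 0.05 h
Compound 3 `CC[C@H](N)C(=O)N1CCc2c(C)c3c(n2-c2ccc(C(N)=O)c(c2)N[C@@H](C)[C@H](C)C1)CC(C)(C)CC3=O`: 0.417 h

In an in vitro ADME assay on microsomes (Homo sapiens) for metabolic stability (on this read-out higher numbers stand for a longer-lived compound and lower numbers for a shorter-lived compound), compound 3 gives 0.417 h, within the scatter of compound 1 and well clear of compound 2. Compound 4 `Cc1c2c(n3c1CCN(C(=O)C(C)(C)N)C[C@@H](C)[C@H](C)Nc1cc-3ccc1C(N)=O)CC(C)(C)CC2=O` carries 1-amino-1-methylethyl in place of 1-aminopropyl on a carbonyl carbon. Within the data shown here, the only measured step at this place is modest: an 8.3-fold higher number from compound 2 to compound 3 (0.92 log units; beyond the scatter), with 1-aminopropyl in place of methyl. That step replaced a methyl group, whereas the new change swaps 1-aminopropyl for a group with the same counts. Among the measured compounds shown here, no measured step compares these two groups, so a change beyond the scatter is not expected, and the expected step is a 1.1-fold higher number from compound 3 to compound 4 (0.03 log units; within the scatter). For compound 4 the estimate is 0.45 h, with an expected range of 0.2 h to 1 h.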

Compound 4, half-life: 0.417 h
For compound 4 the middle estimate is 1.1-fold (0.03 log units) above the measured one; low and high end bracket the measured number.
By their numbers in this assay, from the lowest: compound 2; then compounds 3, 4 and 1 (each within the scatter of the next).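

In this assay, 1-amino-1-methylethyl in place of 1-aminopropyl on this carbonyl carbon gives no change at the digits printed from compound 3 to compound 4 (within the scatter), so losing the defined stereocentre of 1-aminopropyl leaves the half-life within the scatter. Set against methyl, 1-amino-1-methylethyl gives an 8.3-fold higher number from compound 2 to compound 4 (0.92 log units; beyond the scatter), which matches the step seen with 1-aminopropyl, so two differently joined amino-bearing groups both stand clear of methyl here. Nothing available explains these numbers. Still open, on these data alone, is whether the amine matters or the size of the group does: a hydroxyl in place of the amino group, or a longer chain, could separate the two.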